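This account rests on a few compounds, and the source may have more. Where it says the series, first, only, none or still open, it means among the compounds named here.

Within the data shown here, compound 1 `COc1ncc(-c2ccc3c(c2)N(c2ccc(C)cc2)C(=O)CO3)cc1NS(=O)(=O)c1ccc(F)cc1` is the only member of the series with a numerical result: in a functional assay on HeLa cells (Homo sapiens) for antiproliferative activity, read by MTT assay, with a stated time of 72 h (a lower number here means a stronger inhibitor, a higher number a weaker inhibitor), compound 1 gives 4650 nM. Compound 2 `Cc1ccc(N2C(=O)COc3ccc(-c4cccc(NS(=O)(=O)c5ccc(F)cc5)c4)cc32)cc1` returns only a limit, namely (the limit of > 40000 nM in this assay, at which 1 of the 2 values shown sits); in this assay compound 2 gives > 40000 nM. Compound 3 `COc1ncc(-c2ccc3c(c2)N(c2ccccc2)C(=O)CO3)cc1NS(=O)(=O)c1ccc(F)cc1` differs from compound 1 by hydrogen in place of methyl on an aromatic carbon. Among the measured compounds shown here, no measured pair carries this change, so the step expected in this assay is a 1.3-fold higher number from compound 1 to compound 3 (0.11 log units; within the scatter), a move that should stay within the usual scatter, if anything towards slightly weaker inhibition. Compound 3 is accordingly estimated at 6000 nM, with a range of 2500 nM to 15000 nM.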

Compound 3, half-maximal inhibitory concentration: 1530 nM
Compound 3: middle estimate off by 3.9-fold (0.59 log units), on the high side, outside the stated range (below it).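

In this assay, going from 4-methylphenyl to phenyl gives a 3.0-fold lower number from compound 1 to compound 3 (0.48 log units; beyond the scatter), so this site is not indifferent to the methyl group and the estimate of no real change does not hold. The methyl is a liability here, at least on the core of compound 1, where the unsubstituted phenyl is the stronger of the pair. Nothing in the data shown accounts for this step.

As far as these compounds go, whether other groups at this site, such as a methoxy, a chlorine atom or an amine, would move the number in the same direction remains open. From the compounds shown here alone, the finding rests on a single pair, so whether it holds on another core is also open.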